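The source may hold more compounds than are shown below. What is called first, only, known or untested is meant among the compounds shown, and "the series" means these compounds.

Measured so far:
- compound 1, `CCNc1nc(-c2ccccc2)nc2c1nnn2Cc1ccccc1Cl` — 463000000 nM
- compound 2, `COc1ccc(C(=O)Nc2nc(-c3ccccc3)nc3c2nnn3Cc2ccccc2Cl)cc1` — 20000000 nM

Among the compounds with values here, only two compounds have numbers in an assay on isolated protein for binding affinity to adenosine receptor A1 (Bos taurus); on this read-out higher numbers stand for weaker inhibition and lower numbers for stronger inhibition. Within the data shown here, compound 1 gives 463000000 nM and compound 2 gives 20000000 nM, so compound 2 has the lower of the two numbers; its nearest neighbour is compound 1, and the single known step is a 23-fold lower number from compound 1 to compound 2 (1.36 log units; beyond the scatter), which is beyond the scatter and large.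

Compound 3, `Clc1ccccc1Cn1nnc2c(NC3CCCC3)nc(-c3ccccc3)nc21`, is not yet measured in this assay. It differs from compound 2 by cyclopentyl in place of (4-methoxyphenyl)carbonyl on a nitrogen on an aromatic ring. Among the measured compounds shown here, no measured step covers this exact change. For the measured compounds named here, the one step that bears on it runs the other way: going from an alkyl group on that nitrogen (ethyl, compound 1) to the (4-methoxyphenyl)carbonyl group of compound 2 gave a 23-fold lower number from compound 1 to compound 2 (1.36 log units; beyond the scatter). Compound 3 puts an alkyl group, cyclopentyl, back on the same nitrogen, so the expectation is a step back toward the number of compound 1, that is a higher number, though cyclopentyl is not ethyl and the size of the step is uncertain. The expected step is a 5.0-fold higher number from compound 2 to compound 3 (0.70 log units; beyond the scatter). Compound 3 is therefore estimated at 100000000 nM, with a range from 15000000 nM to 600000000 nM.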

Compound 3, inhibition constant: 9000000 nM
Estimate against measurement, compound 3: 11-fold (1.05 log units) above; the whole stated range lies above it.
By their numbers in this assay, from the lowest: compound 3; then compound 2; then compound 1.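

Replacing (4-methoxyphenyl)carbonyl with cyclopentyl on the nitrogen gives a 2.2-fold lower number from compound 2 to compound 3 (0.35 log units; beyond the scatter) in this assay, so the return to a carbon-only group did not move the number back toward that of compound 1. Cyclopentyl in place of ethyl gives a 51-fold lower number from compound 1 to compound 3 (1.71 log units; beyond the scatter) on the same nitrogen, which shows that the two carbon-only groups are far apart and that the carbonyl group is not needed for the lowest number among these three compounds; compound 1 shows that a carbon-only group does not guarantee a low number either. No available evidence accounts for this order of the three groups.

The compounds shown leave open whether the number falls further with cyclohexyl or with a longer chain such as butyl on this nitrogen, and whether the ring of cyclopentyl matters more than its carbon count, which isopropyl or an open pentyl chain would help to separate. They also leave open whether the same order holds when the rest of the shared core carries other groups.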